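The source may hold more compounds than are shown below. What is called first, only, known or untested is meant among the compounds shown, and "the series" means these compounds.

Working notes on the amide series.

Compound 1 `O=C(NC1CCN(Cc2ccc3ccccc3c2)CC1)c1ccc(F)c(F)c1` and compound 2 `O=C(NC1CCN(Cc2ccc3ccccc3c2)CC1)c1cc(F)cc(F)c1` share the core and differ only in the fluorine pattern on the ring attached to the carbonyl carbon. In an assay on isolated protein for binding affinity to melanin-concentrating hormone receptor 1 (Homo sapiens) (a higher number here means a weaker inhibitor, a lower number a stronger inhibitor), compound 1 gives 18 nM and compound 2 gives 65 nM, so compound 2 holds the highest of the two numbers; the step of a 3.6-fold higher number from compound 1 to compound 2 (0.56 log units; beyond the scatter) lies beyond the scatter.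

Compound 3 `COc1cc(C(=O)NC2CCN(Cc3ccc4ccccc4c3)CC2)ccc1F` is the next analogue: 4-fluoro-3-methoxyphenyl in place of 3,5-difluorophenyl on a carbonyl carbon. For the measured compounds named here, the only measured step that bears on this position is a 3.6-fold higher number from compound 1 to compound 2 (0.56 log units; beyond the scatter), which shows that moving a fluorine out of the 4-position raised the number; compound 3 restores a fluorine at the 4-position while bringing in a methoxy in place of the other fluorine. Compound 3 is therefore expected to move back toward compound 1 in this assay, with a step of a 2.6-fold lower number from compound 2 to compound 3 (0.41 log units; beyond the scatter) that is expected to be beyond the scatter. The estimate for compound 3 in this assay is 25 nM, within the range 8 nM to 80 nM.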

Compound 3, inhibition constant: 13 nM
For compound 3 the middle estimate is 1.9-fold (0.28 log units) above the measured one; measured number inside the range.
By their numbers in this assay, from the lowest: compounds 3 and 1 (each within the scatter of the next); then compound 2.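

In this assay, the change from 3,5-difluorophenyl to 4-fluoro-3-methoxyphenyl gives a 5.0-fold lower number from compound 2 to compound 3 (0.70 log units; beyond the scatter), while methoxy in place of fluoro on an aromatic carbon gives a 1.4-fold lower number from compound 1 to compound 3 (0.14 log units; within the scatter), so this replacement does not separate the two compounds. Across these three compounds, the 3,4-difluorophenyl and 4-fluoro-3-methoxyphenyl amides both stand apart from the 3,5-difluorophenyl amide, which has the highest number, and the step of a 3.6-fold higher number from compound 1 to compound 2 (0.56 log units; beyond the scatter) is no longer the only reading at this place. Nothing available here accounts for these differences.

The compounds shown leave open whether the fluorine of 4-fluoro-3-methoxyphenyl is needed for this result, since neither a plain 3-methoxyphenyl amide nor a 3,4-dimethoxyphenyl amide is among them. They also leave open whether an ethoxy group or a nitrile could take the place of the methoxy with a similar number.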